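Toward a trifluoromethoxy analogue in the cytotoxicity series

A few compounds are considered here, and "the series" means these few. Any claim that something is new, unique, unknown or untested is made for them only; others in the source may bear on it.

Compound 1 `CCOC(=O)c1c(-c2ccccc2)[nH]c2cc(OC)ccc2c1=O` in an ADME assay on HepG2 cells (Homo sapiens) for cytotoxicity, read by luminescence, with a stated time of 72 h (a lower number here means that less compound is needed, a higher number that more compound is needed for the effect), gives > 21500 nM, a limit of the assay.
Compound 2 `CCOC(=O)c1c(-c2cccc(C)c2)[nH]c2cc(OC)ccc2c1=O` in this assay gives > 21500 nM, also a limit.
Compound 3 `CCOC(=O)c1c(-c2cccc(OC(C)C)c2)[nH]c2cc(OC)ccc2c1=O` in this assay gives > 21500 nM, again a limit.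

Compound 2 therefore stands at the limit, as do the two others, which is all that the limit of > 21500 nM in this assay, at which 3 of the 3 values shown sit, records. The three steps among them, a step that the two limits leave unreadable from compound 1 to compound 2, a step that the two limits leave unreadable from compound 1 to compound 3 and a step that the two limits leave unreadable from compound 2 to compound 3, cannot be read. Every value is a limit. Compound 4 `CCOC(=O)c1c(-c2cccc(OC(F)(F)F)c2)[nH]c2cc(OC)ccc2c1=O` is not yet measured; it differs from compound 2 in one place: trifluoromethoxy in place of methyl on an aromatic carbon. Methyl and isopropoxy on that aromatic carbon both left the value at the limit, so no readable step bears on this change. The step from compound 2 to compound 4 is accordingly expected to be a step that the limit leaves unreadable from compound 2 to compound 4, with the result most likely reported again as a limit. For compound 4 the expected value in this assay is 30000 nM, within 15000 nM to 80000 nM.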

Compound 4, half-maximal effective concentration: > 21500 nM
Compound 4: only a limit was reported (the forecaster's own chance of this, stated with the estimate: 80%); the middle value lies beyond the limit too.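

Compound 4 joins compound 1, compound 2 and compound 3 as a limit in this assay, so none of the steps among them can be read: the limit of > 21500 nM in this assay, at which 4 of the 4 values shown sit.

The compounds shown leave open where any of them would reach the half-maximal effect, and whether hydrogen, methyl, isopropoxy and trifluoromethoxy on that aromatic carbon differ at all.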